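The source may report more compounds than this note shows. Statements on the series, on what has been measured and on what is new or still open speak of the compounds shown alone.

Measured so far:
- compound 1 `COc1ccc([C@H]2CC(=O)N(Cc3cccc(N)c3)C2)cc1OC1CCCC1`: in a functional assay on HEK293 cells (Homo sapiens) for cytotoxicity (a higher number here means that more compound is tolerated, a lower number that less compound is tolerated), compound 1 gives > 10000 nM, which is a limit of the assay and not a number.
- compound 2 `COc1ccc([C@H]2CC(=O)N(C(=O)c3ccccc3)C2)cc1OC1CCCC1`: in this assay compound 2 gives > 10000 nM, again a limit of the assay rather than a number.

For the measured compounds named here, compound 1 therefore stands only at a limit in this assay; no exact value for it is known, and the same holds for the one further value shown. Going by the values given here, the only measured step, a step that the two limits leave unreadable from compound 1 to compound 2, cannot be read, since both ends sit at the limit: the limit of > 10000 nM in this assay, at which 2 of the 2 values shown sit.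

Compound 3 `COc1ccc([C@H]2CC(=O)N(c3ccc(C)c(N)c3)C2)cc1OC1CCCC1` differs from compound 1 by a rearrangement of the same atoms: 3-amino-4-methylphenyl in place of 3-aminobenzyl on an amide-type nitrogen in a ring. Among the compounds with values here, no measured step bears directly on this change, and the one step that exists gives no readable size. The expectation is therefore that compound 3 behaves like compound 1 and is tolerated up to the limit, so that a step that the limit leaves unreadable from compound 1 to compound 3 is expected to be no step beyond the scatter. The estimate for compound 3 in this assay is 20000 nM, expected within 8000 nM to 60000 nM, most likely reported again as a limit.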

Compound 3, half-maximal cytotoxic concentration: > 10000 nM
Compound 3: no number, only a limit; the forecaster's own chance of this, stated with the estimate: 85%; the middle value does not contradict the limit.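

In this assay compound 3 gives > 10000 nM, which is a limit of the assay and not a number. Its steps from compound 1 and compound 2 therefore cannot be read: the limit of > 10000 nM in this assay, at which 3 of the 3 values shown sit. The compounds shown leave open what concentration each one would need to reach before harming these cells, and whether the groups on the ring nitrogen change that concentration.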